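The source may hold more compounds than are shown below. What is called first, only, known or untested is meant among the compounds shown, and "the series" means these compounds.

Compound 1 `Cc1nc(-c2ccccc2)c(C(=O)N2CCN(c3ccc(Cl)c(Cl)c3)CC2)o1`: 124 nM
Compound 2 `COc1ccc(-c2nc(C)oc2C(=O)N2CCN(c3cccc(Cl)c3)CC2)cc1O`: "not active" (no number reported)
Compound 3 `COc1cccc(N2CCN(C(=O)c3oc(C)nc3-c3cccc(F)c3)CC2)c1`: "not active" (no number reported)

Of the compounds shown here, three built on a shared core have been tested in a functional assay on HL-60 cells (Homo sapiens) for inhibition, read by MTT assay, with a stated time of 72 h; on this read-out lower numbers stand for stronger inhibition and higher numbers for weaker inhibition. Only compound 1 has a number: in this assay compound 1 gives 124 nM. Compound 2 was reported as "not active" (no number reported), with no number attached. Compound 3 was reported the same way, as "not active" (no number reported). So compound 2 stands among the two compounds for which no single number exists, and nothing shows how far it lies from compound 1.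

Compound 4 `COc1ccc(-c2nc(C)oc2C(=O)N2CCN(c3cccc(Cl)c3)CC2)cc1OC` has not yet been measured. It differs from compound 2 in one place: methyl in place of hydrogen on an oxygen on an aromatic ring. Among the compounds with values here, no pair of measured compounds shows what this particular change does, so no step size can be read from the data. Given that compound 2 is recorded as "not active" (no number reported), the most likely outcome is that compound 4 is again reported without a number; if a number appears, it is expected to be far weaker than that of compound 1. Compound 4 is expected to give about 30000 nM, with a range from 5000 nM to 100000 nM.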

Compound 4, half-maximal inhibitory concentration: "not active" (no number reported)
Compound 4: no number reported; no gap can be computed for the estimate.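

Compound 2 and compound 4 were both reported as "not active" with no number attached, so no step can be read for going from hydroxy to methoxy, and no measured evidence bears on this result. The compounds shown leave open how this change would act on a compound that has a number in this assay.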